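The compounds below may be only part of what the source reports. "The series", "measured", "known", "first", "only" and "open" are said of these compounds alone.

Of the compounds shown here, three have been tested in a functional assay on HepG2 cells (Homo sapiens) for antiproliferative activity, read by MTT assay, with a stated time of 72 h (on this read-out lower numbers stand for stronger inhibition and higher numbers for weaker inhibition), and all share one core with variations on the amide and on the ring system that carries it. Compound 1 `C=C(Cl)C(=O)Nc1cc(Nc2nccc(-c3cn(C)c4ccccc34)n2)c(OC)cc1N(C)CCN(C)C` gives 1390 nM. Compound 2 `C=CC(=O)Nc1cc(Nc2nccc(-c3cn(C)c4ccc(F)cc34)n2)c(OC)cc1N(C)CCN(C)C` gives 429 nM. Compound 3 `C=CC(=O)Nc1cc(Nc2ncc(C#N)c(-c3cn(C)c4ccc(F)cc34)n2)c(OC)cc1N(C)CCN(C)C` gives 17500 nM, the highest of the three numbers, and the step of a 41-fold higher number from compound 2 to compound 3 (1.61 log units; beyond the scatter) shows how much that single change moved the read-out. Compound 1 and compound 2 differ in two places at once, so their two values can only be set side by side, not traced to one change.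

Compound 4 `CCC/C=C\C(=O)Nc1cc(Nc2ncc(C#N)c(-c3cn(C)c4ccc(F)cc34)n2)c(OC)cc1N(C)CCN(C)C` keeps everything in compound 3, including the cyano group, and changes only the amide: pent-1-en-1-yl in place of vinyl on a carbonyl carbon. Within the data shown here, none of the measured steps touches this part of the molecule, so there is no direct guide for the size or direction of the move; the only hint is that compound 3 already sits well above the rest. Among the measured compounds shown here, with no comparable step to lean on, the expected move is a 1.4-fold higher number from compound 3 to compound 4 (0.15 log units; within the scatter), a modest rise that stays close to the starting point. Compound 4 is therefore estimated at 25000 nM, with a plausible range from 8000 nM to 80000 nM.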

Compound 4, half-maximal inhibitory concentration: 2010 nM
For compound 4 the middle estimate is 12-fold (1.09 log units) above the measured one, and the stated range ends above it.
By their numbers in this assay, from the lowest: compound 2; then compounds 1 and 4 (each within the scatter of the next); then compound 3.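

Among these compounds, the group on the carbonyl carbon, which no earlier step had touched, turns out to matter: in this assay, pent-1-en-1-yl in place of vinyl gives an 8.7-fold lower number from compound 3 to compound 4 (0.94 log units; beyond the scatter), a change beyond the scatter toward stronger inhibition. This step runs in the opposite direction to the cyano step, a 41-fold higher number from compound 2 to compound 3 (1.61 log units; beyond the scatter), so a compound carrying cyano can still move to a much lower number through a change on the carbonyl carbon alone. Nothing measured here accounts for the lower number that comes with the larger group.

Going by these compounds, the step is read only with cyano present, so it remains open whether the same exchange would shift the number by a similar amount with hydrogen on that aromatic carbon instead. On these data alone, it is also open how the read-out would respond to a still longer chain such as hept-1-en-1-yl, or to a vinyl group carrying a dimethylamino group, on the same carbonyl carbon.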